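Saturated Ring in Place of Phenyl on a Long Amide Chain

This account rests on a few compounds, and the source may have more. Where it says the series, first, only, none or still open, it means among the compounds named here.

Three amides carrying long carbon chains have been tested in a functional assay on PANC-1 cells (Homo sapiens) for cytotoxicity, read by WST assay, with a stated time of 24 h; on this read-out lower numbers stand for stronger inhibition and higher numbers for weaker inhibition. Compound 1 `O=C(/C=C/CCCCCCc1ccccc1)N[C@H]1CC[C@H](O)CC1` reaches only the limit of the assay, giving > 100000 nM. Compound 2 `O=C(CCCCCCc1ccccc1)N1CCCCC1` likewise stops at the limit, at > 100000 nM. Compound 3 `O=C(CCCCCCCc1ccccc1)N1CCCCC1` also sits at the limit, with > 100000 nM. The step that the two limits leave unreadable from compound 2 to compound 3 therefore cannot be read, since (the limit of > 100000 nM in this assay, at which 3 of the 3 values shown sit). Compound 4 `O=C(CCCCCCCCC1CCCCC1)N1CCCCC1` is the next member, and its change from compound 3 is cyclohexylmethyl in place of phenyl on a saturated chain carbon, seven bonds along the chain from a carbonyl carbon. Among the compounds with values here, no measured step bears on this change, and with every earlier value at the limit there is no direction to expect beyond the scatter, only a further limit. Compound 4 is therefore expected to give about 150000 nM, between 50000 nM and 500000 nM. The expected step that the limit leaves unreadable from compound 3 to compound 4 is thus essentially none.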

Compound 4, half-maximal inhibitory concentration: > 100000 nM
Compound 4 was reported as a limit; the forecaster's own chance of this, stated with the estimate: 85%; the middle value does not contradict the limit.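

No step can be read from compound 3 to compound 4, since both stop at a limit: the limit of > 100000 nM in this assay, at which 4 of the 4 values shown sit. From the compounds shown here alone, whether any long-chain amide of this kind gives a measurable value in this assay stays open.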